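Growing the ring on the nitrogen of compound 1

This account rests on a few compounds, and the source may have more. Where it says the series, first, only, none or still open, it means among the compounds named here.

Three compounds share one core and differ only in the group carried on an aromatic nitrogen of that core, or in a single extra substituent. Compound 1 `CC(C)c1onc(-c2c(Cl)cccc2Cl)c1COc1ccc(-c2nc3ccc(C(=O)O)cc3n2C(C)C)cc1` gives 3.39 nM in an assay on Huh-7 cells for agonist activity at Bile acid receptor (Homo sapiens), read by a luciferase reporter (on this read-out lower numbers stand for an effect already at smaller amounts and higher numbers for an effect only at larger amounts of compound), and so has the lowest number of the three. Compound 2 `CC(C)c1onc(-c2c(Cl)cccc2Cl)c1COc1ccc(-c2nc3ccc(C(=O)O)cc3n2C2CCCC2)cc1` gives 13.6 nM, and compound 3 `CC(C)c1onc(-c2c(Cl)cccc2Cl)c1COc1ccc(-c2nc3ccc(C(=O)O)cc3n2C)cc1Cl` gives 19 nM; each of them sits beyond the scatter from compound 1.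

Compound 4 `CC(C)c1onc(-c2c(Cl)cccc2Cl)c1COc1ccc(-c2nc3ccc(C(=O)O)cc3n2C2CCCCCC2)cc1` has not yet been measured. It differs from compound 1 in one place: cycloheptyl in place of isopropyl on an aromatic nitrogen. For the measured compounds named here, the only measured step that bears on this change is the one from isopropyl to cyclopentyl at the same nitrogen, which was a 4.0-fold higher number from compound 1 to compound 2 (0.60 log units; beyond the scatter). Cycloheptyl is a larger ring still, so the same direction is expected, and the step from compound 1 to compound 4 is expected to be at least as large, a 10-fold higher number from compound 1 to compound 4 (1.01 log units; beyond the scatter). Because the step is read from a single pair, the expectation is wide. Compound 4 is therefore estimated to give about 35 nM, with a likely range from 10 nM to 120 nM in this assay.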

Compound 4, half-maximal effective concentration: 14.8 nM
The estimate for compound 4 lay 2.4-fold (0.37 log units) above the measured number; measured number inside the range.
By their numbers in this assay, from the lowest: compound 1; then compounds 2, 4 and 3 (each within the scatter of the next).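

Replacing isopropyl with cycloheptyl on this aromatic nitrogen gives a 4.4-fold higher number from compound 1 to compound 4 (0.64 log units; beyond the scatter), so a second, larger ring also sits above compound 1 in this assay. The two rings can now be compared directly, with a 1.1-fold higher number from compound 2 to compound 4 (0.04 log units; within the scatter): in these compounds the number does not keep climbing as the ring grows from cyclopentyl to cycloheptyl, and the two ring compounds cannot be told apart. Nothing available here explains why both rings sit above isopropyl or why the ring size makes no readable difference between them.

The compounds shown leave open whether smaller rings, such as cyclopropyl or cyclobutyl, would stay close to compound 1 or fall with the larger rings, and so where between isopropyl and cyclopentyl the step arises. They also leave open how this nitrogen would respond to a ring holding an oxygen atom, such as tetrahydropyranyl, to a ring holding an amine, such as piperidinyl, or to an open chain such as n-butyl.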